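The source may report more compounds than this note shows. Statements on the series, on what has been measured and on what is new or still open speak of the compounds shown alone.

In an in vivo functional assay on the whole organism for inhibition, with Rattus norvegicus as the target (on this read-out higher numbers stand for an effect only at larger amounts of compound and lower numbers for an effect already at smaller amounts), compound 1 `CCCCc1nc(C)c(CC(=O)N2CCSCC2)c(=O)n1Cc1ccc(-c2ccccc2-c2nnn[nH]2)cc1` gives 0.038 mg/kg and compound 2 `CCCCc1nc(C)c(CCC(=O)N2CCCC2)c(=O)n1Cc1ccc(-c2ccccc2-c2nnn[nH]2)cc1` gives 0.206 mg/kg, so compound 2 holds the higher of the two numbers. Compound 3 `CCCCc1nc(C)c(CC(=S)N(CC)CC)c(=O)n1Cc1ccc(-c2ccccc2-c2nnn[nH]2)cc1` is still unmeasured, and the change to follow from compound 2 is a group of 7 heavy atoms (5 carbon, 1 nitrogen, 1 sulfur; no ring) in place of a group of 8 heavy atoms (6 carbon, 1 nitrogen, 1 oxygen; one five-membered non-aromatic ring with 1 hetero atom), on a saturated chain carbon bound to an aromatic carbon.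

Among the compounds with values here, only one measured step bears on this change: a 5.4-fold higher number from compound 1 to compound 2 (0.73 log units; beyond the scatter). It is a modest step beyond the scatter, and it falls on the same kind of place, a saturated chain carbon bound to an aromatic carbon. It shows that exchange at this place can move the number, but it cannot be carried over directly. Within the data shown here, no measured compound carries the entering group, which has no ring and contains sulfur.

Among the measured compounds shown here, with only two measured values, compound 2 sits at the upper end of what has been seen, and a modest move toward a lower number is expected in this assay. The expected change is a 2.3-fold lower number from compound 2 to compound 3 (0.36 log units; beyond the scatter). For compound 3 the estimated value is 0.09 mg/kg, with an estimated range of 0.025 mg/kg to 0.3 mg/kg.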

Compound 3, dose for half-maximal effect: 0.023 mg/kg
Compound 3: middle estimate off by 3.9-fold (0.59 log units), on the high side, and the stated range ends above it.
By their numbers in this assay, from the lowest: compounds 3 and 1 (each within the scatter of the next); then compound 2.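

In this assay, the entering group, with no ring and with sulfur, replaces ((pyrrolidin-1-yl)carbonyl)methyl on a saturated chain carbon bound to an aromatic carbon and gives a 9.0-fold lower number from compound 2 to compound 3 (0.95 log units; beyond the scatter), the largest step seen so far at this place and the first to show that a group with no ring can carry a low number here. The same group in place of the six-membered ring group of compound 1 gives a 1.7-fold lower number from compound 1 to compound 3 (0.22 log units; within the scatter), so that ring is not a condition for a number at this level, and compound 2 stands alone at the higher end of the three. Nothing available on these compounds accounts for either step.

The step from compound 2 changes the ring, the sulfur and the heavy-atom count together, so their separate shares remain open, and the matching open-chain diethyl amide with a carbonyl oxygen in place of sulfur is not among the compounds shown. As far as these compounds go, how a carboxylic acid or a primary amine would read at this place also remains open.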